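Working notes: hydroxy in place of aminomethyl

The source may hold more compounds than are shown below. What is called first, only, known or untested is meant among the compounds shown, and "the series" means these compounds.

Measured so far:
Compound 1 `C[C@H](Oc1cccc(Cl)c1Cl)C(=O)Nc1ccc2oc(C3=CC=NCC3=O)nc2c1` — in an assay on isolated protein for inhibition of GMP reductase 2 (Homo sapiens), read by spectrophotometry (a higher number here means a weaker inhibitor, a lower number a stronger inhibitor), compound 1 gives > 5000 nM, a limit of the assay.
Compound 2 `C[C@H](Oc1cccc(Cl)c1Cl)C(=O)Nc1ccc2oc(-c3ccc(CN)cc3)nc2c1` — in this assay compound 2 gives > 5000 nM, again a limit of the assay and not a number.

Among the compounds with values here, compound 2 therefore stands only at the limit in this assay; the one further value is a limit too, so it cannot be placed relative to anything. Within the data shown here, the only step between measured compounds, a step that the two limits leave unreadable from compound 1 to compound 2, is unreadable in size and direction. The evidence on the whole series reduces to one point: the limit of > 5000 nM in this assay, at which 2 of the 2 values shown sit.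

Compound 3 `C[C@H](Oc1cccc(Cl)c1Cl)C(=O)Nc1ccc2oc(-c3ccc(O)cc3)nc2c1` differs from compound 2 by hydroxy in place of aminomethyl on an aromatic carbon. Among the measured compounds shown here, no measured step bears on this change, since the only step in hand is unreadable. With both measured values at the limit, no size or direction can be taken from the data; the working assumption is that compound 3 stays where its parent sits.

Compound 3 is expected in this assay at about 10000 nM, with a range of 4000 nM to 40000 nM. The step that the limit leaves unreadable from compound 2 to compound 3 is expected to be no more than scatter, and most likely a limit will again be reported.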

Compound 3, inhibition constant: > 5000 nM
Compound 3 gave a limit, no number; the forecaster's own chance of this, stated with the estimate: 80%; the middle value does not contradict the limit.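

Within the data shown here, no step among compound 1, compound 2 and compound 3 can be read in this assay, since compound 3 also gives a limit and not a number. The series still rests on one point: the limit of > 5000 nM in this assay, at which 3 of the 3 values shown sit.

The compounds shown leave open how these three rank against each other and which change to the shared core, if any, would give a measurable value in this assay.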